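The source may report more compounds than this note shows. Statements on the series, on what has been measured and on what is new or still open speak of the compounds shown alone.

Compound 2 `Nc1c2c(=O)[nH]c(-c3ccccc3)cc2nn1-c1ccccc1` stands highest of the three compounds measured in an assay on isolated protein for inhibition of ribosomal protein S6 kinase alpha-1 (Homo sapiens), read by mobility shift assay, tested at 30 uM (a higher number here means more inhibition at the concentration tested (going by the name of the read-out), a lower number less inhibition), where compound 2 gives 38%. Compound 1 `CC(C)(C)c1cc2nn(-c3ccccc3)c(N)c2c(=O)[nH]1` gives 5% in this assay, and compound 3 `Nc1c2c(=O)[nH]c(-c3ccccn3)cc2nn1-c1ccccc1` gives 6%. The step of a number 33 percentage points higher from compound 1 to compound 2 (beyond the scatter) shows that a phenyl in place of tert-butyl on an aromatic carbon raised the number, while the step of a number 1 percentage points higher from compound 1 to compound 3 (within the scatter) shows that pyridin-2-yl in that same place left it unchanged. The step of a number 32 percentage points lower from compound 2 to compound 3 (beyond the scatter) is the one that bears most directly on the compound now in question.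

Compound 4 `Nc1c2c(=O)[nH]c(-c3ccccc3)cc2nn1-c1ccccn1` differs from compound 2 by pyridin-2-yl in place of phenyl on an aromatic nitrogen. Within the data shown here, the only measured step with the same pair of groups is the one from compound 2 to compound 3, which was large and downward, but there the exchange was on an aromatic carbon, not on an aromatic nitrogen, so its size cannot simply be carried over. A downward step beyond the scatter is nevertheless the expectation, and for compound 4 the estimated step is a number 23 percentage points lower from compound 2 to compound 4 (beyond the scatter). In this assay compound 4 is therefore expected to give about 15%, with a range from 0% to 40%.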

Compound 4, a percentage reported as inhibition, at one concentration (the size of the read-out at that concentration, not a potency): 5%
Estimate against measurement, compound 4: 10 percentage points above, within the range that was stated.
By their numbers in this assay, from the lowest: compounds 1, 4 and 3 (each within the scatter of the next); then compound 2.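

In this assay the exchange of phenyl for pyridin-2-yl on the aromatic nitrogen proved as costly as it had been on the aromatic carbon: the new step, a number 33 percentage points lower from compound 2 to compound 4 (beyond the scatter), stands beside the earlier a number 32 percentage points lower from compound 2 to compound 3 (beyond the scatter), and both are large and beyond the scatter. Among these compounds, the position on the aromatic nitrogen, which the earlier compounds had not varied, therefore responds to this change, and the loss seen on the aromatic carbon is not confined to that one place. Among the compounds shown, compound 2 with its two phenyl groups is the only one that stands clear of the scatter, and each of the single changes to it that are listed gives a much lower number, though nothing measured here gives a reason for the drop.

Still open, on these data alone, is whether any ring is needed on the aromatic nitrogen, which a methyl group or a small alkyl chain there would test. Also open, as far as these compounds go, is whether a phenyl carrying a fluorine, a methoxy group or an amine at this place would keep or raise the number seen for compound 2.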